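A few compounds are considered here, and "the series" means these few. Any claim that something is new, unique, unknown or untested is made for them only; others in the source may bear on it.

Three compounds have been measured in a functional assay on LoVo cells (Homo sapiens) for inhibition, read by MTT assay, with a stated time of 24 h; on this read-out lower numbers stand for stronger inhibition and higher numbers for weaker inhibition:

Compound 1 `COc1ccc(-n2cc(CN3C(=O)C[C@@H]4CC[C@@]3(C)C4(C)C)nn2)cc1` gives 70 nM.
Compound 2 `COc1cccc(-n2cc(CN3C(=O)C[C@@H]4CC[C@@]3(C)C4(C)C)nn2)c1` gives 80 nM.
Compound 3 `CC1(C)[C@H]2CC[C@]1(C)N(Cc1cn(-c3ccc(Br)cc3)nn1)C(=O)C2` gives 60 nM.

Compound 3 carries the lowest of these three numbers, but the steps of a 1.2-fold lower number from compound 1 to compound 3 (0.07 log units; within the scatter) and a 1.3-fold lower number from compound 2 to compound 3 (0.12 log units; within the scatter) both lie within the scatter, so the three compounds cannot be told apart on these data. The same shared core, a triazole linked through a methylene to a bicyclic lactam, appears in all of them; only the aryl group on the triazole nitrogen changes.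

Compound 4 `CC1(C)[C@H]2CC[C@]1(C)N(Cc1cn(-c3ccccc3F)nn1)C(=O)C2` continues this series. Its change from compound 3 is 2-fluorophenyl in place of 4-bromophenyl on an aromatic nitrogen. Two of the measured steps bear on it. The step of a 1.2-fold lower number from compound 1 to compound 3 (0.07 log units; within the scatter) swaps one halogen-type or methoxy group for another at the same place on the phenyl ring, and the step of a 1.1-fold higher number from compound 1 to compound 2 (0.06 log units; within the scatter) moves a group around the phenyl ring; both are within the scatter. The change to compound 4 combines a swap of the halogen with a move of its place on the ring, so no step beyond the scatter is expected in this assay in either direction.

Compound 4 is therefore estimated at 70 nM, with a range from 35 nM to 140 nM, a step of a 1.2-fold higher number from compound 3 to compound 4 (0.07 log units; within the scatter) that is expected to stay within the scatter.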

Compound 4, half-maximal inhibitory concentration: 40 nM
Estimate against measurement, compound 4: 1.8-fold (0.24 log units) above, within the range that was stated.
By their numbers in this assay, from the lowest: compounds 4, 3, 1 and 2 (each within the scatter of the next).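

Until now the aromatic nitrogen had carried 4-methoxyphenyl, 3-methoxyphenyl or 4-bromophenyl, and 2-fluorophenyl now joins them without a step that stands out from the scatter in this assay (a 1.5-fold lower number from compound 3 to compound 4 (0.18 log units; within the scatter) and a 1.8-fold lower number from compound 1 to compound 4 (0.24 log units; within the scatter) and a 2.0-fold lower number from compound 2 to compound 4 (0.30 log units; within the scatter)). Going by these compounds alone, this is the first case where the halogen and its place on the phenyl ring both differ from those of an earlier compound, yet the two changes together still give a difference too small to read, so the four compounds cannot be ranked on these data. Nothing is available here that could explain the result.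

The compounds shown leave open whether any group at this position can produce a step beyond the scatter, for example a phenyl ring carrying an amine or a carboxylic acid, or a longer alkyl chain in place of the ring. They also say nothing about how much the shared core itself contributes, since it is the same in all four compounds.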